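The source may hold more compounds than are shown below. What is called first, only, known or untested is meant among the compounds shown, and "the series" means these compounds.

Measured compounds in the series:

Compound 1, `NS(=O)(=O)c1ccc(Nc2ncc(/N=C/c3ccc(C(F)(F)F)cc3)c(NC3CCCC3)n2)cc1`. In a functional assay on HeLa cells (Homo sapiens) for antiproliferative activity, read by MTT assay (on this read-out lower numbers stand for stronger inhibition and higher numbers for weaker inhibition), compound 1 gives 21900 nM.
Compound 2, `CC(C)Nc1nc(Nc2ccc(N3CCN(C)CC3)cc2)ncc1/N=C/c1ccc(C(F)(F)F)cc1`. In this assay compound 2 reaches only the limit > 100000 nM.
Compound 3, `CC(C)Nc1nc(Nc2ccc(S(N)(=O)=O)cc2)ncc1/N=C/c1ccccc1`. In this assay compound 3 likewise reaches only the limit > 100000 nM.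

Compound 3 thus stands at the weak end of what has been measured: its result is a limit, not a number, and the same holds for compound 2, so that two of three values sit at the limit of > 100000 nM in this assay, at which 2 of the 3 values shown sit. Only compound 1 gives a numerical value.

The next compound, compound 4, `CC(C)Nc1nc(Nc2ccc(S(N)(=O)=O)cc2)ncc1/N=C/c1ccc(C(F)(F)F)cc1`, differs from compound 3 in one place: trifluoromethyl in place of hydrogen on an aromatic carbon. Going by the values given here, the trifluoromethyl group is the one also present in compound 1 and compound 2. Whether its entry alone carries compound 3 from the limit to a measurable value cannot be read from a measured step, since none exists between compounds differing in this one place.

The expectation is a step from compound 3 to compound 4 of an at least 2.0-fold lower number from compound 3 to compound 4 (0.30 log units; that floor lies within the scatter), toward stronger inhibition but with a sizeable chance that the limit is reported again. Compound 4 is estimated at 50000 nM, with a range from 15000 nM to 150000 nM.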

Compound 4, half-maximal inhibitory concentration: > 100000 nM
Compound 4: only a limit was reported; the forecaster's own chance of this, stated with the estimate: 45%; middle value at least 2.0-fold (0.30 log units) away from the limit.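

In this assay compound 4 is reported only as a limit, > 100000 nM. With isopropyl on the nitrogen, going from phenyl to 4-(trifluoromethyl)phenyl therefore gives no numerical value, and the steps to compound 4 from compound 2 and from compound 3 cannot be read, since both ends of each are limits. The only readable step concerns the other site, where isopropyl stands in place of cyclopentyl on a nitrogen on an aromatic ring, and it is an at least 4.5-fold higher number from compound 1 to compound 4 (0.65 log units; beyond the scatter), so among the compounds shown the one numerical value belongs to the cyclopentyl compound, with the rest of the series at one limit: the limit of > 100000 nM in this assay, at which 3 of the 4 values shown sit.

As far as these compounds go, it remains open what hydrogen in place of trifluoromethyl would do in compound 1, where a change at that site could be read as a number rather than lost at the limit. From the compounds shown here alone, it also remains open whether a cyclohexyl ring or a longer chain such as n-butyl on that nitrogen, or a carboxylic acid or an amine in place of trifluoromethyl, would move the value of compound 1 in either direction.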